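Hydroxamate placement on the anilide of a hydantoin series

This account rests on a few compounds, and the source may have more. Where it says the series, first, only, none or still open, it means among the compounds named here.

Two hydantoin-based hydroxamic acids are characterised so far in an assay on isolated protein for inhibition of protein deacetylase HDAC6 (Homo sapiens), read by fluorescence, with stated times of 5 min and 60 min; a higher number here means a weaker inhibitor, a lower number a stronger inhibitor. Compound 1, `Cc1ccc(CN2C(=O)N(c3ccc(Cl)cc3)C(=O)C2CCC(=O)Nc2cccc(C(=O)NO)c2)cc1`, returns only a limit in this assay, > 40 nM, and no number. Going by the values given here, compound 2, `O=C(CCC1C(=O)N(c2ccc(Cl)cc2)C(=O)N1Cc1ccccc1)Nc1ccc(C(=O)NO)cc1`, gives 7.6 nM in this assay, the only numerical value shown for the pair. The other entry, that of compound 1, is a limit, (the limit of > 40 nM in this assay, at which 1 of the 2 values shown sits).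

Compound 3, `O=C(CCC1C(=O)N(c2ccc(Cl)cc2)C(=O)N1Cc1ccccc1)Nc1cccc(C(=O)NO)c1`, has not yet been measured in this assay. It keeps the core of compound 2 and differs only in the change (3-(hydroxycarbamoyl)phenyl in place of 4-(hydroxycarbamoyl)phenyl on an amide-type nitrogen); cut one bond further out, the swap reads (4-(hydroxycarbamoyl)phenyl)amino to (3-(hydroxycarbamoyl)phenyl)amino. Among the compounds with values here, no step between measured compounds is available that isolates this rearrangement, so its effect cannot be read from the series itself.

For compound 3 the expectation is a loss of potency beyond the usual scatter, a 7.9-fold higher number from compound 2 to compound 3 (0.90 log units; beyond the scatter), with the estimate resting on the measured value of compound 2 and on the direction suggested by the limit of compound 1. The estimated value for compound 3 in this assay is 60 nM, within a range from 15 nM to 250 nM.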

Compound 3, half-maximal inhibitory concentration: > 40 nM
Compound 3: no number, only a limit; the forecaster's own chance of this, stated with the estimate: 45%; the middle value is on the limit's open side.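

Going by these compounds alone, the move from 4-(hydroxycarbamoyl)phenyl to 3-(hydroxycarbamoyl)phenyl on an amide-type nitrogen, with the rest of the molecule unchanged, is the first single-place change that can be read in this assay, and it gives an at least 5.2-fold higher number from compound 2 to compound 3 (0.72 log units; beyond the scatter). In this series, the position of the hydroxycarbamoyl group on the anilide ring therefore matters on its own, and the printed size is a lower bound on the loss, for compound 3 gives only a limit, > 40 nM, and not a number. Compound 3 also shows the 3-(hydroxycarbamoyl)phenyl group at this limit without the methyl carried by compound 1, although the step between them, hydrogen in place of methyl on an aromatic carbon, cannot be read: the limit of > 40 nM in this assay, at which 2 of the 3 values shown sit.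

On these data alone, how far compound 3 lies past its limit stays open, as does any effect of the methyl, which has not been seen on a compound that gives a number in this assay. Also open, as far as these compounds go, is whether the preference for 4-(hydroxycarbamoyl)phenyl survives a longer chain between the core and the anilide, or a carboxylic acid in place of the hydroxycarbamoyl group.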